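A few compounds are considered here, and "the series" means these few. Any claim that something is new, unique, unknown or untested is made for them only; others in the source may bear on it.

Working notes on the series. Compound 2 `O=C(/C=C/c1cccc(O)c1)CC(=O)/C=C/c1cccc(O)c1O` gives 8200 nM in a physicochemical assay for solubility, using the shake flask method, with a stated time of 12 h; a lower number here means a less soluble compound, a higher number a more soluble compound. Compound 1 `O=C(/C=C/c1ccc(O)c(O)c1)CC(=O)/C=C/c1cccc(O)c1O` differs from compound 2 by hydroxy in place of hydrogen on an aromatic carbon; in this assay compound 1 gives 3800 nM, a step of a 2.2-fold lower number from compound 2 to compound 1 (0.33 log units; beyond the scatter). Compound 3 `O=C(/C=C/c1cccc(O)c1)CC(=O)/C=C/c1cc(O)ccc1O` differs from compound 2 in the core, (2,5-dihydroxyphenyl in place of 2,3-dihydroxyphenyl on a double-bonded chain carbon bound to a double-bonded chain carbon); in this assay compound 3 gives 5800 nM, a step of a 1.4-fold lower number from compound 2 to compound 3 (0.15 log units; within the scatter). Compound 4 `O=C(/C=C/c1cc(O)ccc1O)CC(=O)/C=C/c1cc(O)ccc1O` is not yet measured and differs from compound 3 by hydroxy in place of hydrogen on an aromatic carbon, the same kind of change as that from compound 2 to compound 1, though here the entering hydroxy sits ortho to a large group and para to a hydroxy group, whereas before it sat ortho to a hydroxy group and para to a large group. Resting on the single precedent a 2.2-fold lower number from compound 2 to compound 1 (0.33 log units; beyond the scatter), a comparable step is expected, a 2.1-fold lower number from compound 3 to compound 4 (0.32 log units; beyond the scatter). Compound 4 is therefore estimated at 2800 nM in this assay, between 1500 nM and 5500 nM.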

Compound 4, solubility: 5000 nM
Compound 4: middle estimate off by 1.8-fold (0.25 log units), on the low side, and the stated range covers the measured number.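

In this assay the hydroxy entering the core of compound 3 gives a 1.2-fold lower number from compound 3 to compound 4 (0.06 log units; within the scatter) and so lies within the scatter, while the step beyond the scatter seen as a 2.2-fold lower number from compound 2 to compound 1 (0.33 log units; beyond the scatter) does not recur at that size on this core. This rests on a single pair per core, and the entering hydroxy stands ortho to a large group and para to a hydroxy group only in compound 4, so the effect of the core cannot be separated from that of the place. No measurement bears on why the two steps differ.

Open, from the compounds shown here alone, is how a second hydroxy would behave at other places on either core. Also open, going by these compounds, is whether an amine or a carboxylic acid entering in place of hydroxy would follow either step.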